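A few compounds are considered here, and "the series" means these few. Any claim that something is new, unique, unknown or untested is made for them only; others in the source may bear on it.

Measured compounds:
compound 1 `Cc1ncc([N+](=O)[O-])n1CC(=O)NS(=O)(=O)c1ccc(Cl)cc1`: 0.92 ug/mL
compound 2 `O=C(Cc1ccc(F)cc1)NS(=O)(=O)c1ccc(Cl)cc1`: 6.36 ug/mL

In a functional assay on B16-F10 cells (Mus musculus) for antiproliferative activity, read by MTT assay, with a stated time of 48 h (a lower number here means a stronger inhibitor, a higher number a weaker inhibitor), compound 1 gives 0.92 ug/mL, the lowest of the two numbers seen so far. Compound 2 gives 6.36 ug/mL in this assay, a higher number, and the two values stand apart by more than the usual scatter. For the measured compounds named here, no pair of measured compounds differs in a single place, so no measured step is available to calibrate the next change.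

Compound 3 `Cc1ncc([N+](=O)[O-])n1CC(=O)NS(=O)(=O)c1ccc(Br)cc1` differs from compound 1 by bromo in place of chloro on an aromatic carbon. The shared core, the nitroimidazole-bearing acyl sulfonamide, is kept as it stands in compound 1. Going by the values given here, for a change of this kind the series holds no precedent, and the expected step from compound 1 to compound 3 is small, in no settled direction, and within the scatter: a 1.1-fold lower number from compound 1 to compound 3 (0.03 log units; within the scatter). Compound 3 is therefore estimated at 0.85 ug/mL in this assay, with a range from 0.35 ug/mL to 2 ug/mL.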

Compound 3, half-maximal inhibitory concentration: 2.37 ug/mL
Estimate against measurement, compound 3: 2.8-fold (0.45 log units) below, outside the stated range (above it).
By their numbers in this assay, from the lowest: compound 1; then compound 3; then compound 2.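

For the compounds shown here, this is the first single-place step, and it shows that the halogen at this position is not a silent choice: in this assay there is a 2.6-fold higher number from compound 1 to compound 3 (0.41 log units; beyond the scatter) while the shared core stays as it is. The 4-chlorophenyl to 4-bromophenyl exchange swaps one heavy atom for one heavy atom and changes no count of hydrogen-bond donors or acceptors, yet the modest step lies beyond the scatter. Nothing available explains this step.

As far as these compounds go, with only two halogens compared at this position, it remains open whether a fluoro, methyl, methoxy or nitrile group, or plain hydrogen, would give a lower or higher number than chloro. Also open, from the compounds shown here alone, is whether bromo in place of chloro would give a similar step on the core of compound 2.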